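A few compounds are considered here, and "the series" means these few. Any claim that something is new, unique, unknown or untested is made for them only; others in the source may bear on it.

Three close relatives of one shared core have been measured in an assay on membranes from HeLa cells for displacement of a labelled ligand from adenosine receptor A3 (Homo sapiens), read by scintillation counting, with a stated time of 180 min, tested at 1 uM; on this read-out lower numbers stand for less inhibition and higher numbers for more inhibition at the one concentration tested (going by the name of the read-out). Compound 1 `CCCC(=O)C1=C(C)NC(=O)NC1c1ccoc1` gives 2% in this assay. Compound 2 `CCCC(=O)C1=C(C)NC(=O)NC1c1cccs1`, which carries thiophen-2-yl in place of furan-3-yl on a saturated ring carbon, gives 2%, and that step is no change at the digits printed from compound 1 to compound 2 (within the scatter). Compound 3 `CC1=C(c2ncc(C)o2)C(c2cccs2)NC(=O)N1`, with 5-methyl-1,3-oxazol-2-yl in place of propylcarbonyl on a double-bonded ring carbon, gives 1%, a step of a number 1 percentage points lower from compound 2 to compound 3 (within the scatter). Compound 2 therefore stands level with compound 1 at the digits printed, and compound 3 lies within the scatter of both; all three numbers are small, meaning little of the labelled ligand is displaced.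

Compound 4 `CC1=C(C(=O)OC2CCCCC2)C(c2cccs2)NC(=O)N1` differs from compound 2 by cyclohexyloxy in place of propyl on a carbonyl carbon. Going by the values given here, of the two measured steps, only the step from compound 2 to compound 3 touches the propylcarbonyl group at all, and it exchanged the whole group without moving the number beyond the scatter; the other step altered a saturated ring carbon and also stayed within the scatter. Among the compounds with values here, nothing measured so far has shifted this read-out. The expectation for compound 4 is therefore a step of no change at the digits printed from compound 2 to compound 4 (within the scatter) in this assay, that is, no change beyond the scatter. Compound 4 is estimated at 2%, within a range from 0% to 10%.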

Compound 4, a percentage reported as inhibition, at one concentration (the size of the read-out at that concentration, not a potency): 1%
For compound 4 the middle estimate is 1 percentage points above the measured one, within the range that was stated.
By their numbers in this assay, from the lowest: compounds 3, 4, 1 and 2 (each within the scatter of the next).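

In this assay, cyclohexyloxy in place of propyl on a carbonyl carbon gives a number 1 percentage points lower from compound 2 to compound 4 (within the scatter), so a bulkier group carrying a six-membered non-aromatic ring of carbon only and a hydrogen-bond acceptor leaves the number inside the scatter. Compound 3 had exchanged the whole propylcarbonyl group, whereas compound 4 keeps the carbonyl and changes only what sits on it, which adds a second, more local change at this part of the molecule that also fails to lift the read-out out of the low range seen for compounds 1 to 3. The data give no explanation for this flat result.

On these data alone, what stays open is whether any group on this carbonyl carbon can raise the inhibition at all, for example an amine, a benzyloxy group or a longer chain such as hexyl in place of propyl. With every number this small and taken at a single concentration, the four compounds also cannot show whether this position matters for the receptor, since changes in either direction would need a clearly higher starting value to be seen.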